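The compounds below may be only part of what the source reports. "The series", "measured", "known", "first", "only" and "open" are said of these compounds alone.

Compound 1 `Cc1nc(-c2ccc(F)cc2)oc1-c1csc(Cc2ccc(F)cc2)n1`: in an ADME assay on PANC-1 cells (Homo sapiens) for inhibition, read by MTT assay (a lower number here means a stronger inhibitor of growth, a higher number a weaker inhibitor of growth), compound 1 gives > 250 ug/mL, which is a limit of the assay rather than a number.
Compound 2 `Cc1nc(-c2ccc(F)cc2)oc1-c1csc(Cc2ccccc2)n1`: in this assay compound 2 gives > 250 ug/mL, also a limit of the assay and not a number.

Compound 2 therefore stands at the edge of what this assay could measure, with no number of its own. Compound 1 sits at the same edge, so that (the limit of > 250 ug/mL in this assay, at which 2 of the 2 values shown sit). Among the measured compounds shown here, the one measured step, a step that the two limits leave unreadable from compound 1 to compound 2, cannot be read, since both of its ends are limits.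

Compound 3 `Cc1nc(-c2ccc(F)cc2)oc1-c1csc(Cc2cccc(Cl)c2)n1` differs from compound 2 by chloro in place of hydrogen on an aromatic carbon. The measured step also changes the benzyl ring, but it carries no readable size, so it offers no measured amount of change to carry over to this assay in either direction. Compound 3 is accordingly expected to stay near the same limit, at an estimated 300 ug/mL with a range from 100 ug/mL to 800 ug/mL. The step that the limit leaves unreadable from compound 2 to compound 3 is thus expected to be small, within the scatter, if it appears at all.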

Compound 3, concentration for 50% growth inhibition: > 250 ug/mL
Compound 3 was reported as a limit; the forecaster's own chance of this, stated with the estimate: 70%; the middle value does not contradict the limit.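

In this assay compound 3 gives > 250 ug/mL, a limit of the assay and not a number. The steps to compound 3 from compound 1 and compound 2 therefore cannot be read. The compounds shown leave open how strongly any of them inhibits growth, and whether changing the benzyl group alters that at all, as all three share one edge: the limit of > 250 ug/mL in this assay, at which 3 of the 3 values shown sit.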